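The source may hold more compounds than are shown below. What is called first, only, known or untested is meant among the compounds shown, and "the series" means these compounds.

In an ADME assay on microsomes from liver (Homo sapiens) for metabolic stability, read by HPLC, with a stated time of 30 min, tested at 0.5 uM (a higher number here means faster removal of the compound, a lower number slower removal), compound 1 (`CCC/N=C1\S/C(=C\c2ccc(O)cn2)C(=O)N1c1ccccc1C`) gives 2.8 mL.min-1.g-1 and compound 2 (`CCC/N=C1\S/C(=C\c2ccc(O)c(Br)c2)C(=O)N1c1ccccc1C`) gives 1.6 mL.min-1.g-1 on the same scale. Compound 3 (`CCC/N=C1\S/C(=C\c2ccc(O)c(C)c2)C(=O)N1c1ccccc1C`) gives 2.8 mL.min-1.g-1 and so stands level with compound 1 at the digits reported, as no change at the digits printed from compound 1 to compound 3 (within the scatter) shows. Its distance from the remaining compound is a 1.8-fold higher number from compound 2 to compound 3 (0.24 log units; within the scatter) and this is the largest gap it has so far.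

The next compound is compound 4 (`CCC/N=C1\S/C(=C\c2ccc(O)c(Cl)c2)C(=O)N1c1ccccc1C`). The change is chloro in place of methyl on an aromatic carbon and it places chloro in place of methyl on an aromatic carbon, ortho to a hydroxy group and meta to a large group. Among the compounds with values here, the closest precedent is a 1.8-fold higher number from compound 2 to compound 3 (0.24 log units; within the scatter) since it too exchanges a single group on an aromatic carbon, with bromo in the place of chloro. The wider exchange of the whole aromatic group gave a 1.8-fold lower number from compound 1 to compound 2 (0.24 log units; within the scatter) and did not leave the scatter either. Within the data shown here, no chloro compound has been measured yet. Among the measured compounds shown here, no measured step in this small set lies beyond the scatter, so none is expected here, with any drift more likely downward. The expected step is a 1.3-fold lower number from compound 3 to compound 4 (0.10 log units; within the scatter) and it stays within the scatter. Compound 4 is estimated at 2.2 mL.min-1.g-1 with an expected range from 1.3 mL.min-1.g-1 to 3.6 mL.min-1.g-1 in this assay once it is measured.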

Compound 4, intrinsic clearance in microsomes in the Homo sapiens assay: 1.6 mL.min-1.g-1
Compound 4: middle estimate off by 1.4-fold (0.14 log units), on the high side, within the range that was stated.
By their numbers in the Homo sapiens assay, from the lowest: compounds 2, 4, 1 and 3 (each within the scatter of the next).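

Within the data shown here, in the Homo sapiens assay, chloro and bromo at this position, ortho to a hydroxy group, read alike, with no change at the digits printed from compound 2 to compound 4 (within the scatter), whereas chloro in place of methyl gives a 1.8-fold lower number from compound 3 to compound 4 (0.24 log units; within the scatter), a step the same size as the one between bromo and methyl, and a 1.8-fold lower number from compound 1 to compound 4 (0.24 log units; within the scatter) places the chloro phenol the same distance from the hydroxypyridine; every one of these steps stays within the scatter, so the set shows no separation at this position, only two halogen compounds sharing one printed number and a methyl compound sharing another with compound 1. In a physicochemical assay for solubility, measured as kinetic solubility (a lower number here means a less soluble compound, a higher number a more soluble compound), the same exchange of methyl for chloro gives a 1.0-fold higher number from compound 3 to compound 4 (0.01 log units; within the scatter), so this pair also shows no separation in the physicochemical assay, with compound 3 at 78000 nM and compound 4 at 79000 nM. Nothing available on these compounds bears on the reason for these numbers.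

As far as these compounds go, whether a group such as methoxy, a nitrile or an amine at this position would give a step beyond the scatter in the Homo sapiens assay remains open. Also open, from the compounds shown here alone, is whether a carboxylic acid here, or a longer chain in place of the propyl chain, would shift the number in the physicochemical assay.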